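The compounds below may be only part of what the source reports. "The series", "measured", "known", "first", "only" and "open" are said of these compounds alone.

Measured compounds:
- compound 1 `O=C1/C(=C/c2ccccc2F)CN(Cc2cn(Cc3ccccc3F)nn2)C/C1=C\c1ccccc1F`; in a functional assay on 4T1 cells (Mus musculus) for cytotoxicity, read by MTT assay, with a stated time of 24 h (on this read-out higher numbers stand for weaker inhibition and lower numbers for stronger inhibition), compound 1 gives 6500 nM
- compound 2 `O=C1/C(=C/c2ccccc2F)CN(Cc2cn(Cc3ccccc3Cl)nn2)C/C1=C\c1ccccc1F`; in this assay compound 2 gives 5300 nM
- compound 3 `COc1ccc(/C=C2\CN(Cc3cn(Cc4ccccc4Cl)nn3)C/C(=C\c3ccc(OC)cc3)C2=O)cc1`; in this assay compound 3 gives 11400 nM

Compounds 1 and 2 share one core and differ at a single point: fluoro in place of chloro on an aromatic carbon. The step that goes with this change is a 1.2-fold higher number from compound 2 to compound 1 (0.09 log units; within the scatter), so the two values are not separated by this assay.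

Compound 3 carries a different core; how its core differs from that of compound 2 is not broken down here. Compound 3 gives a higher number than compound 2 in this assay, a gap that lies beyond the scatter, while the values of compound 3 and compound 1 lie within the scatter of each other.

Compound 4 `COc1ccc(/C=C2\CN(Cc3cn(Cc4ccccc4F)nn3)C/C(=C\c3ccc(OC)cc3)C2=O)cc1` is not yet measured. It stands to compound 3 as compound 1 stands to compound 2: fluoro in place of chloro on an aromatic carbon. The place lines of the two changes read the same, so this is the same change on a second core. For the measured compounds named here, the only measured instance, the step from compound 2 to compound 1, is small and within the scatter, and no second instance is available to show whether the new core responds differently.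

On that basis the step from compound 3 to compound 4 in this assay is expected to be small, about a 1.1-fold higher number from compound 3 to compound 4 (0.06 log units; within the scatter), because the same change gave a 1.2-fold higher number from compound 2 to compound 1 (0.09 log units; within the scatter). Compound 4 is therefore estimated at 13000 nM, with a range from 6000 nM to 28000 nM.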

Compound 4, half-maximal inhibitory concentration: 39400 nM
Compound 4: middle estimate off by 3.0-fold (0.48 log units), on the low side, and the stated range ends below it.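

In this assay, fluoro in place of chloro on the core of compound 3 gives a 3.5-fold higher number from compound 3 to compound 4 (0.54 log units; beyond the scatter), a step that lies beyond the scatter and points to weaker inhibition with the 2-fluorobenzyl group than with the 2-chlorobenzyl group on this core. Set beside the earlier pair, the change does not carry over at one size from the core of compound 2 to the core of compound 3: the same change on two cores in this assay, a 1.2-fold higher number (0.09 log units; within the scatter) from compound 2 to compound 1 and a 3.5-fold higher number (0.54 log units; beyond the scatter) from compound 3 to compound 4, 2.8-fold (0.45 log units) apart, beyond the scatter of two such steps. For these two pairs, then, the step on one core is a poor guide to the step on the other, but with a single pair on each core this does not show which feature of the cores sets the difference, how well either step would repeat, or what the change would do on a third core.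

The compounds shown hold only chloro and fluoro at this place on the aromatic ring, so it remains open whether a methyl group or a bromo group there would also read differently on the two cores. Also open, on these data alone, is whether the gap between the cores persists when the benzyl group gives way to a longer chain or to a group carrying an amine.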